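The source may hold more compounds than are shown below. What is called first, only, known or untested is meant among the compounds shown, and "the series" means these compounds.

Compounds measured so far in a functional assay on the whole organism (strain NMRI) with Mus musculus as the target, with a stated time of 60 min, at a dose of 20 mg/kg by the intraperitoneal route; on this read-out lower numbers stand for a weaker effect and higher numbers for a stronger effect at the one dose given:

Compound 1, `CSc1nnc(Cc2ccc(Cl)cc2Oc2ccccc2Cl)[nH]1`, gives 170%.
Compound 2, `CCCSc1nnc(Cc2ccc(Cl)cc2Oc2ccccc2Cl)[nH]1`, gives 134%.
Compound 3, `Clc1ccc(Cc2nnc(SCc3ccccc3)[nH]2)c(Oc2ccccc2Cl)c1`, gives 129%.

Compound 2 stands second of the three numbers, yet its distance to compound 3 is only a number 5 percentage points lower from compound 2 to compound 3 (within the scatter), so those two cannot be told apart, while its distance from compound 1 is a number 36 percentage points lower from compound 1 to compound 2 (beyond the scatter), a real gap. The step from compound 1 to compound 3 is a number 41 percentage points lower from compound 1 to compound 3 (beyond the scatter).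

Compound 4, `CCCSc1nnc(Cc2ccc(Cl)cc2Oc2ccccc2F)[nH]1`, has not yet been measured. It differs from compound 2 in one place: fluoro in place of chloro on an aromatic carbon. All three measured steps change the group on the saturated chain carbon bound to a sulfur and leave the phenoxy ring untouched, so none of them bears on this exchange of one halogen for another on that ring. With nothing pointing either way, the expected step is no change at the digits printed from compound 2 to compound 4 (within the scatter), that is, no change beyond the scatter. Compound 4 is therefore expected to give about 134% in this assay, in a range from 105% to 160%.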

Compound 4, a percentage reported as activity, at one dose (the size of the read-out at that dose, not a potency): 133%
Compound 4: middle estimate off by 1 percentage points, on the high side; measured number inside the range.
By their numbers in this assay, from the lowest: compounds 3, 4 and 2 (each within the scatter of the next); then compound 1.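

In this assay, exchanging the 2-chlorophenoxy group for 2-fluorophenoxy leaves the two compounds indistinguishable, with a number 1 percentage points lower from compound 2 to compound 4 (within the scatter). For the compounds shown here, the earlier steps all changed the group on sulfur, and some of those lay beyond the scatter, so this is the first reading on the phenoxy ring: for this one pair, fluoro serves as well as chloro on that aromatic carbon at the single dose given. No measurement at hand offers an explanation for this result.

On these data alone, it remains open whether a hydrogen, a methoxy group or an amine at the same place would also match compound 2. As far as these compounds go, it is also open whether the same halogen exchange would leave the read-out as undisturbed with the methyl group on sulfur that compound 1 carries.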